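Pyridin-2-yl added to the oxadiazole of compound 3

The source may report more compounds than this note shows. Statements on the series, on what has been measured and on what is new or still open speak of the compounds shown alone.

Compound 1 `O=C(CCCCCCc1ccccc1)c1nnc(-c2cccs2)o1`: 0.8 nM
Compound 2 `COC(=O)c1cccc(-c2nnc(C(=O)CCCCCCc3ccccc3)o2)n1`: 3 nM
Compound 3 `O=C(CCCCCCc1ccccc1)c1ncno1`: 1 nM

In an assay for inhibition of Fatty-acid amide hydrolase 1 (Rattus norvegicus), at pH 9.0 (on this read-out higher numbers stand for weaker inhibition and lower numbers for stronger inhibition), compound 3 stands second highest of the three numbers; compound 1 lies within the scatter of it, and compound 2 gives a number beyond the scatter above it. Compound 4 `O=C(CCCCCCc1ccccc1)c1nc(-c2ccccn2)no1` has not been measured. It differs from compound 3 by pyridin-2-yl in place of hydrogen on an aromatic carbon. Among the compounds with values here, no step between measured compounds shows the effect of such an addition, so the step from compound 3 is expected to be small, in neither direction beyond the scatter: a 1.4-fold lower number from compound 3 to compound 4 (0.15 log units; within the scatter). Compound 4 is thus estimated at 0.7 nM, within 0.15 nM to 4 nM.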

Compound 4, inhibition constant: 0.34 nM
Estimate against measurement, compound 4: 2.1-fold (0.31 log units) above; measured number inside the range.
By their numbers in this assay, from the lowest: compound 4; then compounds 1 and 3 (each within the scatter of the next); then compound 2.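

On the carbon between two ring nitrogen atoms, this assay gives the first readable step: pyridin-2-yl in place of hydrogen produces a 2.9-fold lower number from compound 3 to compound 4 (0.47 log units; beyond the scatter). This position therefore accepts a six-membered aromatic ring without loss of inhibition, and the change strengthens inhibition modestly. Nothing available explains this gain. The compounds shown leave open whether a phenyl group, lacking the ring nitrogen of pyridin-2-yl, would give a similar step. They also do not show how an amine or a carboxylic acid on this carbon would behave.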